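The compounds below may be only part of what the source reports. "The series", "measured", "known", "first", "only" and "open" are said of these compounds alone.

Three ureas on a shared core have been measured in an assay on CHO cells for displacement of a labelled ligand from adenosine receptor A1 (Homo sapiens), tested at 10 uM; a lower number here means less inhibition, a higher number more inhibition at the concentration tested (going by the name of the read-out). Compound 1 `COc1ccc(OC)c(NC(=O)Nc2nn(-c3ccccc3)c(=O)c3ccccc23)c1` gives 0%, compound 2 `O=C(Nc1ccc(Cl)cc1)Nc1nn(-c2ccccc2)c(=O)c2ccccc12` gives 10%, and compound 3 `COc1ccccc1NC(=O)Nc1nn(-c2ccccc2)c(=O)c2ccccc12` gives 0%. Compound 3 therefore stands level with compound 1 at the digits shown, the two together the lowest of the three numbers, with compound 2 nearest above them. All three steps among them, a number 10 percentage points higher from compound 1 to compound 2 (within the scatter), no change at the digits printed from compound 1 to compound 3 (within the scatter) and a number 10 percentage points lower from compound 2 to compound 3 (within the scatter), are within the scatter.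

The next compound, compound 4 `COc1ccccc1CNC(=O)Nc1nn(-c2ccccc2)c(=O)c2ccccc12`, differs from compound 3 by 2-methoxybenzyl in place of 2-methoxyphenyl on an amide-type nitrogen. Among the measured compounds shown here, none of the measured steps makes the same kind of change: two of them exchange one aryl partner for another on the amide-type nitrogen, and one puts hydrogen in place of methoxy on an aromatic carbon, and every one of them stayed within the scatter while the read-out in this assay remained near the bottom of the scale. With nothing in the data that moved the number, the step expected in this assay is a number 3 percentage points higher from compound 3 to compound 4 (within the scatter), that is, none beyond the scatter. For compound 4 the estimate in this assay is 3%, with a range from 0% to 20%.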

Compound 4, a percentage reported as inhibition, at one concentration (the size of the read-out at that concentration, not a potency): 28%
For compound 4 the middle estimate is 25 percentage points below the measured one, and the stated range ends below it.
By their numbers in this assay, from the lowest: compounds 1, 3 and 2 (each within the scatter of the next); then compound 4.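

Among the compounds shown here, on the amide-type nitrogen whose other neighbour is the carbonyl carbon, 2-methoxybenzyl in place of 2-methoxyphenyl gives the first step beyond the scatter in this assay with a number 28 percentage points higher from compound 3 to compound 4 (beyond the scatter), whereas the exchanges of one aryl partner for another had all stayed within it. The same holds against the other two ureas, with a number 18 percentage points higher from compound 2 to compound 4 (beyond the scatter) and a number 28 percentage points higher from compound 1 to compound 4 (beyond the scatter), so compound 4 stands alone at the top of the four and this position is shown to respond to the change; the entering group holds 9 heavy atoms against 8 while keeping the same six-membered aromatic ring and the same hydrogen-bond counts. Nothing available explains why this change moves the number.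

The compounds shown leave open whether the methoxy group matters once the benzyl is in place, which a plain benzyl or a 4-chlorobenzyl on the same nitrogen would address. They also leave open whether a longer chain such as 2-(2-methoxyphenyl)ethyl would carry the read-out further or lose it again, and a single concentration gives no potency for any of them.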